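The source may report more compounds than this note shows. Statements on the series, on what has been measured and on what is new or still open speak of the compounds shown alone.

For the measured compounds named here, in a functional assay on NCI-H460 cells (Homo sapiens) for inhibition, read by MTT assay, with a stated time of 24 h, tested at 10 ug/mL (on this read-out higher numbers stand for more inhibition of growth at the one concentration tested and lower numbers for less inhibition of growth), compound 1 (`O=C(CCCCC(S)CCS)NO`) gives 17.7% and stands highest of the two numbers available so far. Compound 2 (`O=C(CCCCC(S)CCS)Nc1ccc([N+](=O)[O-])c(C(F)(F)F)c1`) gives 0.97% in this assay and so lies lower, by more than the usual scatter. Compound 3 (`O=C(CCCCC(S)CCS)Nc1ccccn1`) has not yet been measured. Its structure departs from that of compound 1 by pyridin-2-yl in place of hydroxy on an amide-type nitrogen and this amounts to pyridin-2-yl in place of hydroxy on an amide-type nitrogen. Going by the values given here, no measured pair of compounds isolates this change, so the only guide is a single comparison. Compound 2 also carries no hydroxy on that nitrogen, and its 0.97% in this assay suggests that losing the hydroxy may not help. A downward step just beyond the scatter is therefore expected in this assay and the estimated change is a number 10.7 percentage points lower from compound 1 to compound 3 (beyond the scatter) for this replacement. For compound 3 the estimated value is 7% with an expected range of 0% to 20%. That range stays wide. Among the compounds with values here, only two compounds have been measured on this scale, compound 1 at 17.7% and compound 2 at 0.97%.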

Compound 3, percent growth inhibition at one concentration: "not active" (no number reported)
Nothing numeric was reported for compound 3; the estimate stays without a comparison.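

In this assay, for the compounds shown here, compound 3 is reported only as "not active", with no number, so no step from compound 1 to compound 3 can be read. The compounds shown leave open how large any change from hydroxy to pyridin-2-yl on this amide-type nitrogen would be. No measured evidence bears on this result.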